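A few compounds are considered here, and "the series" means these few. Any claim that something is new, unique, unknown or untested is made for them only; others in the source may bear on it.

Working notes on the series, read in a functional assay on LOX IMVI cells (Homo sapiens) for cytotoxicity, read by MTT assay, with a stated time of 24 h; a lower number here means a stronger inhibitor, a higher number a weaker inhibitor. Compound 1 (`COc1cc(-c2nc(-c3ccccc3)[nH]c2-c2ccnc(NCCCNS(=O)(=O)c3cccc(F)c3)n2)ccc1F`) gives 900 nM, and compound 2 (`COc1cc(-c2nc(-c3ccccc3)[nH]c2-c2ccnc(NCCCNS(=O)(=O)c3cccc4ccccc34)n2)ccc1F`) gives 14900 nM. Compound 3 (`COc1cc(-c2nc(-c3ccccc3)[nH]c2-c2ccnc(NCCCNS(=O)(=O)c3ccccc3)n2)ccc1Cl`) gives 7470 nM, a value within the scatter of compound 2 and well above that of compound 1. Compound 4 (`COc1ccc(S(=O)(=O)NCCCNc2nccc(-c3[nH]c(-c4ccccc4)nc3-c3ccc(Cl)c(OC)c3)n2)cc1`) changes phenylsulfonyl to (4-methoxyphenyl)sulfonyl: methoxy in place of hydrogen on an aromatic carbon, para to a large group (methoxy in place of hydrogen on an aromatic carbon). For the measured compounds named here, only one measured step touches the group on the sulfonyl sulfur: a 17-fold higher number from compound 1 to compound 2 (1.22 log units; beyond the scatter). That step is large, but it replaces 3-fluorophenyl with naphthalen-1-yl, which is a different change, and it starts from another compound. Going by the values given here, no measured step adds a methoxy, so the data give no direction. The large size of that single step does keep the range wide. No shift beyond the scatter is expected, and the estimated step is a 1.2-fold lower number from compound 3 to compound 4 (0.10 log units; within the scatter). For compound 4 the estimated value is 6000 nM, with an expected range of 2000 nM to 20000 nM.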

Compound 4, half-maximal inhibitory concentration: 1800 nM
Compound 4: the middle estimate sits 3.3-fold (0.52 log units) above what was measured, and the stated range ends above it.
By their numbers in this assay, from the lowest: compounds 1 and 4 (each within the scatter of the next); then compounds 3 and 2 (each within the scatter of the next).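

In this assay, methoxy in place of hydrogen on an aromatic carbon, para to a large group, gives a 4.2-fold lower number from compound 3 to compound 4 (0.62 log units; beyond the scatter) and so lowers the number. For the compounds shown here, until now, the only measured change to the group on the sulfonyl sulfur was a 17-fold higher number from compound 1 to compound 2 (1.22 log units; beyond the scatter) in the opposite direction, from another starting compound and with a different kind of change. The group on the sulfonyl sulfur can therefore move the number either way, and a single added methoxy is enough for a step beyond the scatter. No measurement shown accounts for this step.

Open, on these data alone, is whether hydroxy or an amine at this same place would move the number in the same direction. Also open, as far as these compounds go, is whether methoxy gives a similar step on the core of compound 1 .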